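Acetylating the Amino Group of Compound 2

This account rests on a few compounds, and the source may have more. Where it says the series, first, only, none or still open, it means among the compounds named here.

compound 1 `CC(=O)Nc1ccc(C(=O)Nc2c(C)cccc2C)cc1`: 19.9 mg/kg
compound 2 `Cc1cccc(CO)c1NC(=O)c1ccc(N)cc1`: 3.9 mg/kg

In a functional assay on the whole organism with Mus musculus as the target, in the maximal electroshock model (on this read-out lower numbers stand for an effect already at smaller amounts and higher numbers for an effect only at larger amounts of compound), compound 2 gives 3.9 mg/kg as the lower of the two numbers, and compound 1 gives 19.9 mg/kg on the same read-out, a gap beyond the scatter. Compound 3 `CC(=O)Nc1ccc(C(=O)Nc2c(C)cccc2CO)cc1` differs from compound 2 by acetyl in place of hydrogen on a nitrogen on an aromatic ring in a change from amino to acetamido. Among the compounds with values here, no single-change step has been measured for this swap. Compound 1 also carries acetamido and shows 19.9 mg/kg as its number, so a move towards a higher number is expected. The estimated step is a 6.4-fold higher number from compound 2 to compound 3 (0.81 log units; beyond the scatter) in that direction. For compound 3 the expected value is 25 mg/kg within an estimated range of 8 mg/kg to 90 mg/kg overall.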

Compound 3, dose for half-maximal effect: > 80 mg/kg
Compound 3: no number, only a limit (the forecaster's own chance of this, stated with the estimate: 30%); at least 3.2-fold (0.50 log units) between middle value and limit.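

In this assay compound 3 gives no number, only a limit: the limit of > 80 mg/kg in this assay, at which 1 of the 3 values shown sits. Acetyl in place of hydrogen on the nitrogen on the aromatic ring therefore carries a large penalty, an at least 20-fold higher number from compound 2 to compound 3 (1.31 log units; beyond the scatter), so amino is far preferred to acetamido when the hydroxy group is present. With acetamido in place, hydroxy in place of hydrogen on the saturated chain carbon also moves the number upward, an at least 4.0-fold higher number from compound 1 to compound 3 (0.60 log units; beyond the scatter). On these data alone, the true size of both steps remains open, as does whether a methyl or a formyl group on this nitrogen would be tolerated.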